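The source may hold more compounds than are shown below. What is called first, only, known or untested is meant among the compounds shown, and "the series" means these compounds.

The series shares one core: compound 1 is `CC(C)(C)OC(=O)N1CCC(O[C@H]2CC[C@H](Oc3cnc(S(C)(=O)=O)cn3)CC2)CC1`, compound 2 is `CS(=O)(=O)c1cnc(O[C@H]2CC[C@H](OC3CCN(C(=O)Oc4ccccc4)CC3)CC2)cn1` and compound 3 is `CS(=O)(=O)c1cnc(O[C@H]2CC[C@H](OC3CCN(CC4(C(F)(F)F)CC4)CC3)CC2)cn1`. In a functional assay on isolated protein for agonist activity at Glucose-dependent insulinotropic receptor (Homo sapiens), read by HTRF and cAMP accumulation (a higher number here means that more compound is needed for the effect, a lower number that less compound is needed), compound 1 gives 5.9 nM, compound 2 gives 9.6 nM and compound 3 gives 62.6 nM, the highest number of the three; the nearest, compound 2, is reached by a 6.5-fold higher number from compound 2 to compound 3 (0.81 log units; beyond the scatter), and the furthest, compound 1, by an 11-fold higher number from compound 1 to compound 3 (1.03 log units; beyond the scatter). Compound 1 and compound 2 differ only by a 1.6-fold higher number from compound 1 to compound 2 (0.21 log units; within the scatter).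

Compound 4 is `CS(=O)(=O)c1cnc(O[C@H]2CC[C@H](OC3CCN(CC4(C(F)(F)F)CCCC4)CC3)CC2)cn1`. It differs from compound 3 by a group of 9 heavy atoms (6 carbon, 3 fluorine; one five-membered non-aromatic ring of carbon only) in place of a group of 7 heavy atoms (4 carbon, 3 fluorine; one three-membered non-aromatic ring of carbon only), on a saturated chain carbon bound to an amine nitrogen in a ring. Among the compounds with values here, none of the measured steps changes the size of this ring: the two larger steps replace the whole group on the ring nitrogen, and the remaining step alters the carbamate of compound 1. What is known therefore gives no direct guide to the size of this step, and in this assay the expectation is a step within the scatter, a 1.1-fold higher number from compound 3 to compound 4 (0.05 log units; within the scatter). Compound 4 is thus expected to give about 70 nM, with a range from 25 nM to 200 nM.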

Compound 4, half-maximal effective concentration: 48.8 nM
Compound 4: the middle estimate sits 1.4-fold (0.16 log units) above what was measured; measured number inside the range.
By their numbers in this assay, from the lowest: compounds 1 and 2 (each within the scatter of the next); then compounds 4 and 3 (each within the scatter of the next).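

Carbon-only rings of three and five members on the saturated chain carbon bound to the amine nitrogen in a ring cannot be told apart in this assay, with a 1.3-fold lower number from compound 3 to compound 4 (0.11 log units; within the scatter). The larger ring also leaves the distance to the two carbamates in place, with a 5.1-fold higher number from compound 2 to compound 4 (0.71 log units; beyond the scatter) and an 8.3-fold higher number from compound 1 to compound 4 (0.92 log units; beyond the scatter), so this change of ring size does not recover the numbers of the tert-butoxycarbonyl and phenoxycarbonyl compounds. No accompanying measurement bears on why these numbers fall as they do.

On these data alone, whether a cyclobutane or cyclohexane ring at this place would fit the same picture remains open. So does what a methyl group in place of trifluoromethyl would do to the number.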